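The source may hold more compounds than are shown below. What is called first, only, known or untested is meant among the compounds shown, and "the series" means these compounds.

Of the compounds shown here, three sharing one core have been measured in a functional assay on NCI-H322M cells (Homo sapiens) for inhibition, read by sulforhodamine B assay, with a stated time of 48 h; on this read-out lower numbers stand for stronger inhibition of growth and higher numbers for weaker inhibition of growth. Compound 1 `CN1CCN(CCCOc2cccc3nc(Nc4ccc(Cl)c(F)c4)ccc23)CC1` gives 1700 nM, compound 2 `CC(C)c1ccc(Nc2ccc3c(OCCCN4CCN(C)CC4)cccc3n2)cc1` gives 11000 nM, and compound 3 `CN1CCN(CCCOc2cccc3nc(Nc4ccc(F)c(F)c4)ccc23)CC1` gives 3930 nM, the second highest of the three numbers. Compound 4 `CN1CCN(CCCOc2cccc3nc(Nc4cccc(Cl)c4)ccc23)CC1` has not yet been measured. Its difference from compound 3 is 3-chlorophenyl in place of 3,4-difluorophenyl on a nitrogen on an aromatic ring. Going by the values given here, no measured compound carries this exact group, so the evidence is indirect. One relevant step is a 2.3-fold higher number from compound 1 to compound 3 (0.36 log units; beyond the scatter), with fluoro in place of chloro on an aromatic carbon, which hints that a chloro group may go with a lower number. Another is a 2.8-fold lower number from compound 2 to compound 3 (0.45 log units; beyond the scatter), which shows only a modest shift when this group is exchanged. A small move towards a lower number is therefore expected, possibly none beyond the scatter. The expected step is a 1.3-fold lower number from compound 3 to compound 4 (0.12 log units; within the scatter). For compound 4 the estimated value is 3000 nM, with an expected range of 1300 nM to 7000 nM.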

Compound 4, concentration for 50% growth inhibition: 2670 nM
Compound 4: the middle estimate sits 1.1-fold (0.05 log units) above what was measured, within the range that was stated.
By their numbers in this assay, from the lowest: compounds 1, 4 and 3 (each within the scatter of the next, the first and the last beyond it); then compound 2.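

In this assay, the 3-chlorophenyl group, with its single chlorine, cannot be told apart from the 3,4-difluorophenyl group, with a 1.5-fold lower number from compound 3 to compound 4 (0.17 log units; within the scatter), or from 4-chloro-3-fluorophenyl, with a 1.6-fold higher number from compound 1 to compound 4 (0.20 log units; within the scatter). Only the exchange for 4-isopropylphenyl gives a step beyond the scatter, a 4.1-fold lower number from compound 2 to compound 4 (0.61 log units; beyond the scatter), leaving compound 2 the weakest of the four, while compound 4 falls within the scatter of both compound 1 and compound 3, although those two differ beyond it. No measurement is available that explains these differences.

The compounds shown leave open how a 3-methoxyphenyl or 3-trifluoromethylphenyl group on this nitrogen would read. Going by these compounds alone, they vary only this group, so the effect of a longer chain on the oxygen of the shared core also remains unknown.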